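A few compounds are considered here, and "the series" means these few. Any claim that something is new, unique, unknown or untested is made for them only; others in the source may bear on it.

In an assay on isolated protein for inhibition of Amine oxidase [flavin-containing] A (Homo sapiens), read by fluorescence and Amplex Red, with a stated time of 30 min, tested at 10 uM (a higher number here means a stronger effect of the compound at the concentration tested, a lower number a weaker effect), the measured compounds stand as follows:

compound 1 `CCCCNc1nnc(SCC(=O)N(Cc2cccc([N+](=O)[O-])c2)c2ccc(F)cc2)s1`: 76%
compound 2 `CCCNc1nnc(SCC(=O)N(Cc2cccc([N+](=O)[O-])c2)c2ccc(F)cc2)s1`: 78.3%
compound 3 `COCCNc1nnc(SCC(=O)N(Cc2cccc([N+](=O)[O-])c2)c2ccc(F)cc2)s1`: 80.6%

Compound 2 gives the second highest of the three numbers. Its nearest neighbour is compound 1: a number 2.3 percentage points higher from compound 1 to compound 2 (within the scatter). Its furthest is compound 3: a number 2.3 percentage points higher from compound 2 to compound 3 (within the scatter). The remaining pair shows a number 4.6 percentage points higher from compound 1 to compound 3 (within the scatter). All three numbers thus sit within the usual scatter of one another.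

Compound 4 `CC(C)Nc1nnc(SCC(=O)N(Cc2cccc([N+](=O)[O-])c2)c2ccc(F)cc2)s1` is the next candidate. The change from compound 2 is isopropyl in place of propyl on a nitrogen on an aromatic ring.

No measured step concerns branching of the chain on this nitrogen; the three steps shown alter the chain by a methyl or a methoxy, and every one of them fell within the scatter. On that basis a step of similar size is expected in this assay, with no direction beyond the scatter. The expected step is a number 0.3 percentage points lower from compound 2 to compound 4 (within the scatter). Compound 4 is therefore estimated at 78%, with a range from 66% to 88%.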

Compound 4, a percentage reported as inhibition, at one concentration (the size of the read-out at that concentration, not a potency): 86.1%
Compound 4: middle estimate off by 8.1 percentage points, on the low side, within the range that was stated.
By their numbers in this assay, from the lowest: compounds 1, 2, 3 and 4 (each within the scatter of the next, the first and the last beyond it).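

Branching on the nitrogen on an aromatic ring now has a direct test. In this assay, the change from propyl to isopropyl gives a number 7.8 percentage points higher from compound 2 to compound 4 (within the scatter), and the change from 2-methoxyethyl to isopropyl gives a number 5.5 percentage points higher from compound 3 to compound 4 (within the scatter), so neither step separates compound 4 from its neighbour. For the compounds shown here, the only step beyond the scatter is modest and spans the two ends of the series, a number 10.1 percentage points higher from compound 1 to compound 4 (beyond the scatter), where isopropyl replaces butyl, while compound 2 and compound 3 remain within the scatter of both ends; no supporting data bear on this result.

A cyclopropyl or tert-butyl group on this nitrogen, or a chain ending in a carboxylic acid or an amine, would extend the comparison. The single-concentration read-out also leaves open whether this separation would hold as a difference in potency.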